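From Hydroxymethyl to Phenoxymethyl on a Shared Core

A few compounds are considered here, and "the series" means these few. Any claim that something is new, unique, unknown or untested is made for them only; others in the source may bear on it.

Measured so far:
Compound 1 `OC[C@H]1CO[C@](Cn2ccnc2)(c2ccc(Cl)cc2Cl)O1` — > 30000 nM
Compound 2 `O=C1c2ccccc2C(=O)N1C[C@H]1CO[C@](Cn2ccnc2)(c2ccc(Cl)cc2Cl)O1` — > 30000 nM

Of the compounds shown here, two have been measured in an assay for binding affinity to Gonadotropin-releasing hormone receptor (Rattus norvegicus), read by radioligand binding; a higher number here means a weaker inhibitor, a lower number a stronger inhibitor. Compound 1 gives > 30000 nM, which is a limit of the assay and not a number. Compound 2 gives > 30000 nM, also a limit. Compound 1 therefore stands nowhere on a scale of numbers: both values shown sit at the same limit (the limit of > 30000 nM in this assay, at which 2 of the 2 values shown sit).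

Compound 3 `Clc1ccc([C@@]2(Cn3ccnc3)OC[C@H](COc3ccccc3)O2)c(Cl)c1` differs from compound 1 by phenyl in place of hydrogen on an oxygen on a saturated carbon, so the hydroxymethyl arm becomes a phenoxymethyl arm. Going by the values given here, no step between measured compounds exists, so neither size nor direction for the change in this assay can be read from a measured pair; with compound 1 at the limit, a shift could appear only as a move into the measurable range.

Compound 3 is expected to give 30000 nM in this assay, with a range of 5000 nM to 100000 nM. That estimate means an expected step of a number no higher from compound 1 to compound 3 (the limit leaves the size open), most likely again a limit.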

Compound 3, half-maximal inhibitory concentration: > 30000 nM
Compound 3: no number, only a limit; the forecaster's own chance of this, stated with the estimate: 70%; the middle value lies on the limit itself.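

Compound 3 gives > 30000 nM, a limit of the assay and not a number. Going by these compounds alone, with compound 1 also at a limit, no step between compound 1 and compound 3 can be read. The compounds shown leave open whether any replacement on the hydroxymethyl arm of the shared core gives a measurable value in this assay.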